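Solubility of a Fused Bicyclic Series: Imidazole for Methyl

This account rests on a few compounds, and the source may have more. Where it says the series, first, only, none or still open, it means among the compounds named here.

Measured compounds:
Compound 1 `CC(C)(C)c1nc(-c2ccc[nH]2)c2cc(C(N)=O)c(N)nc2n1`: 130000 nM
Compound 2 `CC(C)(C)c1ccc2c(N)c(C#N)c(N)nc2n1`: 14200 nM
Compound 3 `Cc1nc(C(C)(C)C)nc2nc(N)c(C#N)c(N)c12`: 37000 nM

The read-out throughout is a physicochemical assay for solubility, in phosphate buffer, with a stated time of 18 h; on this read-out lower numbers stand for lower solubility and higher numbers for higher solubility. Among the three numbers, compound 3 gives 37000 nM, which stands second highest. Its nearest neighbour is compound 2, whose value in this assay is lower by a gap beyond the scatter, and the furthest is compound 1, whose value is higher, again by a gap beyond the scatter. For the measured compounds named here, no two of the measured compounds differ in one place only, so no single step between them can be read off directly.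

Compound 4 `Cc1c[nH]c(-c2nc(C(C)(C)C)nc3nc(N)c(C#N)c(N)c23)n1` has not yet been measured. It differs from compound 3 in one place: 4-methyl-1H-imidazol-2-yl in place of methyl on an aromatic carbon. Nothing in the measured set isolates what this exchange does to the read-out, so the expectation for compound 4 rests on compound 3 alone, with the wide spread of the three values as a caution.

The step expected from compound 3 to compound 4 in this assay is estimated as a 1.2-fold lower number from compound 3 to compound 4 (0.09 log units; within the scatter), which lies within the scatter. Compound 4 is accordingly expected to give about 30000 nM, with a range from 8000 nM to 100000 nM.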

Compound 4, solubility: 5000 nM
Estimate against measurement, compound 4: 6.0-fold (0.78 log units) above; measured number below the stated range.
By their numbers in this assay, from the lowest: compound 4; then compound 2; then compound 3; then compound 1.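

For the compounds shown here, this is the first step that changes one place only: with 4-methyl-1H-imidazol-2-yl in place of methyl on the aromatic carbon meta to a tert-butyl group, this assay shows a 7.4-fold lower number from compound 3 to compound 4 (0.87 log units; beyond the scatter) and so a gap beyond the usual scatter. Going by these compounds alone, the read-out therefore responds to what this carbon carries, which the earlier compounds, none of them a single change from another, could not show. The entering group brings one five-membered aromatic ring with 2 hetero atoms, 1 hydrogen-bond donor and 1 hydrogen-bond acceptor, but no evidence here bears on which of these features, if any, lies behind the step.

From the compounds shown here alone, this one pair cannot separate the ring from its methyl substituent, so it stays open whether an unsubstituted imidazole, a phenyl ring or a small amine on this carbon would give a number nearer that of compound 3 or that of compound 4. Going by these compounds, it also stays open whether the same exchange would give a step of similar size on another core.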